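The compounds below may be only part of what the source reports. "The series", "measured", "known", "first", "only" and "open" are said of these compounds alone.

Of the compounds shown here, two built on one shared core have been measured so far in a physicochemical assay for lipophilicity, read by mass spectrometry; a higher number here means a more lipophilic compound, a lower number a more polar compound. Compound 1 `COc1cc2c(cc1OC)C(=O)C(C(=O)Nc1ccc(Cl)cc1)C2` gives 2.76, and compound 2 `COc1cc2c(cc1OC)C(=O)C(C(=O)Nc1ccccc1C)C2` gives 2.69. These two numbers lie within the usual scatter of repeated measurements, so compound 2 cannot be told apart from compound 1 in this assay.

Compound 3 `COc1ccccc1NC(=O)C1Cc2cc(OC)c(OC)cc2C1=O` has not yet been measured. It differs from compound 2 by methoxy in place of methyl on an aromatic carbon, ortho to a large group (methoxy in place of methyl on an aromatic carbon). The same difference can be read as 2-methylphenyl to 2-methoxyphenyl.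

For the measured compounds named here, no measured step makes this exact swap, so the evidence is indirect. Going by the values given here, the only step available is a number 0.07 log units lower from compound 1 to compound 2 (within the scatter), which came with 2-methylphenyl in place of 4-chlorophenyl on an amide-type nitrogen. It concerns the same aromatic group and is small. On that single step, no change beyond the scatter is expected in this assay. The expected result is a number 0.14 log units lower from compound 2 to compound 3 (within the scatter), and this estimate is too small to be told from the scatter. For compound 3 the estimated value is 2.55, with an expected range from 2.2 to 2.9.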

Compound 3, partition coefficient: 2.08
For compound 3 the middle estimate is 0.47 log units above the measured one, outside the stated range (below it).
By their numbers in this assay, from the lowest: compound 3; then compounds 2 and 1 (each within the scatter of the next).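

In this assay, for the compounds shown here, the aromatic group on the amide nitrogen had so far seemed to matter little, but this position now proves sensitive: methoxy in place of methyl on an aromatic carbon, ortho to a large group, gives a number 0.61 log units lower from compound 2 to compound 3 (beyond the scatter). Going from 4-chlorophenyl to 2-methoxyphenyl gives a step of similar size, a number 0.68 log units lower from compound 1 to compound 3 (beyond the scatter), so compound 3 stands apart from both earlier compounds, which remain within the scatter of each other. Nothing measured here says what lies behind this drop.

As far as these compounds go, the finding rests on a single methyl-to-methoxy pair, so it remains open whether the same swap would lower the number on another core or at another place on this aromatic ring. It is also unclear whether the drop is particular to methoxy or would also appear with a hydroxyl, an ethoxy or an amine at the same carbon, and comparing those groups would show whether the oxygen or the whole methoxy group goes with the lower number.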